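This account rests on a few compounds, and the source may have more. Where it says the series, first, only, none or still open, it means among the compounds named here.

Of the compounds shown here, three sharing one core have been tested in an ADME assay on MT4 cells (Homo sapiens) for cytotoxicity, read by MTT assay; a higher number here means that more compound is tolerated, a lower number that less compound is tolerated. Compound 1, `O=C1c2ccccc2C(=O)N1CCOC(=S)N(C(=O)c1ccccc1[N+](=O)[O-])c1ccc(Cl)cc1`, gives 21000 nM. Compound 2, `O=C1c2ccccc2C(=O)N1CCOC(=S)N(C(=O)c1ccc(F)c(F)c1)c1ccc(Cl)cc1`, gives 52000 nM, and compound 3, `O=C1c2ccccc2C(=O)N1CCOC(=S)N(C(=O)c1cccc(Cl)c1Cl)c1ccc(Cl)cc1`, gives 54000 nM. Among these three numbers compound 1 stands lowest, so it is the one of which the cells tolerate least.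

The next compound, compound 4, is `O=C1c2ccccc2C(=O)N1CCOC(=S)N(C(=O)c1ccc(Cl)c(Cl)c1)c1ccc(Cl)cc1`. Set against compound 1 the difference is 3,4-dichlorophenyl in place of 2-nitrophenyl on a carbonyl carbon.

Within the data shown here, two measured steps bear on this change, since both also swap the 2-nitrophenyl for a halogenated phenyl on the carbonyl carbon. The step of a 2.5-fold higher number from compound 1 to compound 2 (0.39 log units; beyond the scatter) and the step of a 2.6-fold higher number from compound 1 to compound 3 (0.41 log units; beyond the scatter) were both modest and pointed the same way, while the step of a 1.0-fold higher number from compound 2 to compound 3 (0.02 log units; within the scatter) showed that the two halogenated variants are not told apart. A step of similar size and direction is therefore expected for compound 4, namely a 2.4-fold higher number from compound 1 to compound 4 (0.38 log units; beyond the scatter) in this assay.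

On that basis compound 4 is estimated at 50000 nM in this assay, with a likely range from 28000 nM to 90000 nM.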

Compound 4, half-maximal cytotoxic concentration: 35000 nM
Estimate against measurement, compound 4: 1.4-fold (0.15 log units) above; the measured number falls inside the stated range.
By their numbers in this assay, from the lowest: compounds 1, 4, 2 and 3 (each within the scatter of the next, the first and the last beyond it).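

In this assay, replacing 2-nitrophenyl on a carbonyl carbon does not always give a step beyond the scatter: the new step, a 1.7-fold higher number from compound 1 to compound 4 (0.22 log units; within the scatter), stays within it, unlike a 2.5-fold higher number from compound 1 to compound 2 (0.39 log units; beyond the scatter) and a 2.6-fold higher number from compound 1 to compound 3 (0.41 log units; beyond the scatter). Compound 4 also cannot be told apart from either halogenated neighbour, neither with the chlorines placed differently, a 1.5-fold lower number from compound 3 to compound 4 (0.19 log units; within the scatter), nor with fluorines in place of chlorines, a 1.5-fold lower number from compound 2 to compound 4 (0.17 log units; within the scatter). No measurement is at hand that explains these numbers.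

Every group shown on this carbonyl carbon is a substituted phenyl, so the effect of a longer alkyl chain, an amine or a carboxylic acid there remains open. All four compounds share the rest of the core, so these steps say nothing about changes elsewhere in it.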